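The source may report more compounds than this note shows. Statements on the series, on what has been measured and on what is new or still open speak of the compounds shown alone.

Compound 1 `O=C(Nc1nc(-c2ccccc2)cs1)c1ccccc1`: 1290 nM
Compound 2 `Cn1c(-c2ccccc2)cs/c1=N/C(=O)c1ccccc1`: 189 nM

Both compounds were tested in a functional assay on MDA-MB-231 cells (Homo sapiens) for inhibition, read by transwell migration, with a stated time of 24 h; a lower number here means a stronger inhibitor, a higher number a weaker inhibitor. Compound 2 holds the lower of the two numbers at 189 nM, while compound 1 reads 1290 nM, a gap beyond the scatter, and so compound 2 is the stronger inhibitor of the pair. The next compound, compound 3 `Cn1c(-c2ccccc2)cs/c1=N/C(=O)c1ccc(Cl)cc1`, keeps the frame of compound 2 and places chloro in place of hydrogen on an aromatic carbon, para to a large group, turning phenyl into 4-chlorophenyl: chloro in place of hydrogen on an aromatic carbon. For the measured compounds named here, no measured pair here shows what this change does, so only a small shift toward a lower number is expected, one not beyond the scatter. The expected change is a 1.5-fold lower number from compound 2 to compound 3 (0.16 log units; within the scatter). For compound 3 the estimated value in this assay is 130 nM, with an estimated range from 40 nM to 400 nM.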

Compound 3, half-maximal inhibitory concentration: 1120 nM
For compound 3 the middle estimate is 8.6-fold (0.94 log units) below the measured one, outside the stated range (above it).
By their numbers in this assay, from the lowest: compound 2; then compounds 3 and 1 (each within the scatter of the next).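

In this assay, for the compounds shown here, the step from hydrogen to chloro on an aromatic carbon, para to a large group, is the first change at this position to be read, and it costs inhibition (a 5.9-fold higher number from compound 2 to compound 3 (0.77 log units; beyond the scatter)), a step beyond the scatter. It shows that this position is not indifferent to substitution: turning phenyl into 4-chlorophenyl, with one added heavy atom, is enough to give up a clear part of the inhibition held by compound 2. Nothing available here bears on what lies behind this loss.

What stays open is whether the loss belongs to chloro alone or to any group at this position, since the compounds shown include no fluoro, methoxy, amine or carboxylic acid there. They also leave open whether chloro would be tolerated elsewhere on this phenyl ring or on the other one.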